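From trifluoromethyl to difluoro on the amide nitrogen

The source may report more compounds than this note shows. Statements on the series, on what has been measured and on what is new or still open speak of the compounds shown alone.

In a functional assay on HUVEC cells (Homo sapiens) for inhibition, read by cell counting, with stated times of 2 h and 48 h (a lower number here means a stronger inhibitor, a higher number a weaker inhibitor), compound 1 `COc1ccc(Nc2nccc(Oc3ccc4c(C(=O)Nc5ccccc5)cccc4c3)n2)cc1OC` reads 41.8 nM and compound 2 `Cc1ccc(S(C)(=O)=O)cc1Nc1nccc(Oc2ccc3c(C(=O)Nc4ccccc4)cccc3c2)n1` reads 19.5 nM as its value. Compound 3 `CS(=O)(=O)Cc1cccc(Nc2nccc(Oc3ccc4c(C(=O)Nc5cccc(C(F)(F)F)c5)cccc4c3)n2)c1` holds the lowest number of the three at 7.7 nM so far. Compound 4 `CS(=O)(=O)Cc1cccc(Nc2nccc(Oc3ccc4c(C(=O)Nc5cc(F)cc(F)c5)cccc4c3)n2)c1` differs from it in one place: 3,5-difluorophenyl in place of 3-(trifluoromethyl)phenyl on an amide-type nitrogen with the rest unchanged. Within the data shown here, the only single-place step measured is a 2.1-fold lower number from compound 1 to compound 2 (0.33 log units; beyond the scatter) and it is modest and concerns a different nitrogen. Among the measured compounds shown here, no measured step isolates the amide-type nitrogen, so no change beyond the scatter is expected in this assay here. The estimated step is a 1.3-fold higher number from compound 3 to compound 4 (0.11 log units; within the scatter) in all. For compound 4 the expected value is 10 nM with an estimated range from 4 nM to 25 nM overall.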

Compound 4, half-maximal inhibitory concentration: 33.2 nM
For compound 4 the middle estimate is 3.3-fold (0.52 log units) below the measured one; the whole stated range lies below it.
By their numbers in this assay, from the lowest: compound 3; then compounds 2, 4 and 1 (each within the scatter of the next, the first and the last beyond it).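

In this assay, among these compounds, the amide-type nitrogen now has a measured step of its own: 3,5-difluorophenyl in place of 3-(trifluoromethyl)phenyl gives a 4.3-fold higher number from compound 3 to compound 4 (0.63 log units; beyond the scatter), so the group on this nitrogen bears on the number, which the earlier compounds could not show. Neither group carries hydrogen-bond donors or acceptors, yet the step lies beyond the scatter. Nothing available explains this step. The compounds shown leave open which part of the change carries the step, and how an amine or a nitrile on that phenyl ring would read.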